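The source may hold more compounds than are shown below. What is called first, only, known or untested is meant among the compounds shown, and "the series" means these compounds.

Measured compounds:
Compound 1, `CCCCCCC[C@H]1C[C@H](Br)CCN1S(=O)(=O)c1ccc(C)cc1` — in a functional assay on WiDr cells (Homo sapiens) for antiproliferative activity, read by sulforhodamine B assay, with a stated time of 48 h (a lower number here means a stronger inhibitor of growth, a higher number a weaker inhibitor of growth), compound 1 gives > 100000 nM, which is a limit of the assay and not a number.
Compound 2, `Cc1ccc(S(=O)(=O)N2CC[C@@H](Br)C[C@@H]2C2CCCCC2)cc1` — compound 2 gives 14000 nM.
Compound 3, `CCCCCCCC1C=C(Cl)CCN1S(=O)(=O)c1ccc(C)cc1` — compound 3 gives 50000 nM.

Compound 1 and compound 2 share a core and differ in one place: cyclohexyl in place of heptyl on a saturated ring carbon. That change brings an at least 7.1-fold lower number from compound 1 to compound 2 (0.85 log units; beyond the scatter). The size of this step is bounded only on one side, since the value of compound 1 sits at the limit of > 100000 nM in this assay, at which 1 of the 3 values shown sits.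

Compound 3 carries the same heptyl on its own core, and the difference between the core of compound 3 and the core of compound 1 is not broken down here. Of the measured compounds, compound 3 has the highest number; its nearest neighbour is compound 2, whose number is lower by a margin beyond the scatter.

Compound 4, `Cc1ccc(S(=O)(=O)N2CCC(Cl)=CC2C2CCCCC2)cc1`, has not been measured. It differs from compound 3 in one place: cyclohexyl in place of heptyl on a saturated ring carbon. This is the same kind of change as that from compound 1 to compound 2, though around the place the surroundings differ: in compound 3 the place is two ring bonds from the ring atom that bears a chloro group, whereas in compound 1 it is two ring bonds from the ring atom that bears a bromo group. Because the earlier change gave an at least 7.1-fold lower number from compound 1 to compound 2 (0.85 log units; beyond the scatter), a step of similar direction is expected here, a 6.3-fold lower number from compound 3 to compound 4 (0.80 log units; beyond the scatter), though its size is only an expectation since the earlier step is itself bounded by a limit. For compound 4 the estimated value in this assay is 8000 nM, expected to lie between 2000 nM and 30000 nM.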

Compound 4, concentration for 50% growth inhibition: 24000 nM
Compound 4: middle estimate off by 3.0-fold (0.48 log units), on the low side; the measured number falls inside the stated range.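

In this assay, cyclohexyl in place of heptyl on a saturated ring carbon again lowered the number, with a 2.1-fold lower number from compound 3 to compound 4 (0.32 log units; beyond the scatter) on the second core. The direction of the change therefore carried over from the core of compound 1 to the core of compound 3, but its size did not: the same change on two cores in this assay, an at least 7.1-fold lower number (0.85 log units; beyond the scatter) from compound 1 to compound 2 and a 2.1-fold lower number (0.32 log units; beyond the scatter) from compound 3 to compound 4, at least 3.4-fold (0.53 log units) apart, beyond the scatter of two such steps. The earlier step is bounded on one side only, and that gap rests on the same bound, as the value of compound 1 is a limit of the assay and not a number: the limit of > 100000 nM in this assay, at which 1 of the 4 values shown sits.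

The compounds shown leave open how a phenyl group, a shorter chain or a chain ending in an amine would compare with cyclohexyl and heptyl on that saturated ring carbon. They also leave open whether the smaller step goes with the chloro group or with the rest of the core, a question that a pair differing from compound 3 and compound 4 only by a bromo group in place of the chloro group could address.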